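The compounds below may be only part of what the source reports. "The series", "measured", "known", "first", "only" and "open" are said of these compounds alone.

Measured compounds:
- compound 1, `Cc1ccccc1CSc1nnc(-c2ccc3c(c2)OCCO3)n1-c1ccccc1`: 20500 nM
- compound 2, `Cc1ccc(CSc2nnc(-c3ccc4c(c3)OCCO4)n2-c2ccccc2)cc1`: 56800 nM

Both were run in a functional assay on HepG2 cells (Homo sapiens) for antiproliferative activity, read by MTT assay, with a stated time of 24 h; a higher number here means a weaker inhibitor, a lower number a stronger inhibitor. Going by the values given here, compound 2 stands highest of the two numbers; the nearest is compound 1, reached by a 2.8-fold higher number from compound 1 to compound 2 (0.44 log units; beyond the scatter), which is the only measured step.

Compound 3, `Fc1ccc(CSc2nnc(-c3ccc4c(c3)OCCO4)n2-c2ccccc2)c(F)c1`, has not yet been measured. It differs from compound 2 by 2,4-difluorophenyl in place of 4-methylphenyl on a saturated chain carbon bound to a sulfur.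

Among the compounds with values here, the one measured step bears only loosely on this change: it swaps a methyl from one ring position to another, whereas here a 4-methylphenyl gives way to a 2,4-difluorophenyl. Nothing measured shows what a fluorine on this ring does. With compound 2 at the top of the numbers, a modest move downward is the more likely reading, expressed as a 1.9-fold lower number from compound 2 to compound 3 (0.28 log units; within the scatter), though a change within the scatter cannot be ruled out. Compound 3 is therefore estimated at 30000 nM, with a range from 12000 nM to 90000 nM.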

Compound 3, half-maximal inhibitory concentration: 1960 nM
Compound 3: the middle estimate sits 15-fold (1.18 log units) above what was measured, and the stated range ends above it.
By their numbers in this assay, from the lowest: compound 3; then compound 1; then compound 2.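

In this assay the 2,4-difluorophenyl group on a saturated chain carbon bound to a sulfur brings a 29-fold lower number from compound 2 to compound 3 (1.46 log units; beyond the scatter) and, set against 2-methylphenyl, a 10-fold lower number from compound 1 to compound 3 (1.02 log units; beyond the scatter) as well. Both steps are large beside the modest 2.8-fold higher number from compound 1 to compound 2 (0.44 log units; beyond the scatter) seen with the methyl alone moved, so the ring at this place can shift the number much further than the earlier pair showed. Compound 3 now holds the lowest number of the three, with its steps to both others beyond the scatter, and nothing available accounts for this result.

Still open, as far as these compounds go, is whether a single fluorine on this ring, or a bare phenyl, would sit nearer compound 3 or nearer compound 1 and compound 2. Also open, from the compounds shown here alone, is what a chlorine or a methoxy on the ring, or a longer chain between ring and sulfur, would do.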